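A Fluoro Analogue Weighed Against Cyano, Nitro and Chloro

A few compounds are considered here, and "the series" means these few. Any claim that something is new, unique, unknown or untested is made for them only; others in the source may bear on it.

Measured compounds in a functional assay on SW480 cells (Homo sapiens) for cytotoxicity, read by MTT assay, with a stated time of 48 h; on this read-out higher numbers stand for weaker inhibition and lower numbers for stronger inhibition:
compound 1, `N#Cc1ccc(Cn2cc(COc3ccc4c(=O)ccoc4c3)nn2)cc1`: > 100000 nM
compound 2, `O=c1ccoc2cc(OCc3cn(Cc4ccc([N+](=O)[O-])cc4)nn3)ccc12`: 19300 nM
compound 3, `O=c1ccoc2cc(OCc3cn(Cc4ccc(Cl)cc4)nn3)ccc12`: > 100000 nM

Compound 1 gives only a limit of the assay, > 100000 nM, so its own number is not known. Compound 3 likewise sits at a limit, > 100000 nM. Among the measured compounds shown here, compound 2 is the one measured value here, 19300 nM. Two of the three results therefore rest at the limit of > 100000 nM in this assay, at which 2 of the 3 values shown sit.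

The unmeasured compound 4, `O=c1ccoc2cc(OCc3cn(Cc4ccc(F)cc4)nn3)ccc12`, differs from compound 1 by fluoro in place of cyano on an aromatic carbon. For the measured compounds named here, the steps that bear on it are an at least 5.1-fold lower number from compound 1 to compound 2 (0.71 log units; beyond the scatter), an at least 5.1-fold higher number from compound 2 to compound 3 (0.71 log units; beyond the scatter) and a step that the two limits leave unreadable from compound 1 to compound 3. Nitro stands apart from both cyano and chloro, whereas chloro, a halogen like fluoro, returns the same limit as cyano. Compound 4 is thus expected to stay at the limit, with a step that the limit leaves unreadable from compound 1 to compound 4, and no step beyond the scatter is expected. Compound 4 is estimated at 150000 nM, between 40000 nM and 600000 nM.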

Compound 4, half-maximal inhibitory concentration: 11200 nM
Compound 4: the middle estimate sits 13-fold (1.13 log units) above what was measured; the measured number lies below the stated range.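

In this assay, the two halogens at this place, on an aromatic carbon para to a large group, do not read alike, as the result gives an at least 8.9-fold lower number from compound 3 to compound 4 (0.95 log units; beyond the scatter). Replacing the nitrile with fluoro likewise gives an at least 8.9-fold lower number from compound 1 to compound 4 (0.95 log units; beyond the scatter), while the step to fluoro from nitro stays within the scatter, with a 1.7-fold lower number from compound 2 to compound 4 (0.24 log units; within the scatter), so this change leaves compound 2 and compound 4 unseparated. The two larger steps are bounded on one side only, and their full size cannot be read, nor can the step between compound 1 and compound 3, since compound 1 and compound 3 each rest at a limit: the limit of > 100000 nM in this assay, at which 2 of the 4 values shown sit.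

The compounds shown leave open how an amine, a methoxy group or a carboxylic acid would read at this place. They also leave open why fluoro and nitro stand together apart from chloro and the nitrile.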